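Estimating the solubility of compound 3 from compound 1

A few compounds are considered here, and "the series" means these few. Any claim that something is new, unique, unknown or untested is made for them only; others in the source may bear on it.

Among the measured compounds shown here, compound 1 `C[C@H]1[C@H](N)CN1c1nc2c(cc1F)c(=O)c(C(=O)O)cn2C1CC1` holds the only exact reading so far in a physicochemical assay for solubility, at pH 7.4 (on this read-out lower numbers stand for lower solubility and higher numbers for higher solubility), where compound 1 gives 16.5 ug/mL. Compound 2 `C[C@H](N)C(=O)N[C@@H]1CN(c2cc3c(cc2F)c(=O)c(C(=O)O)cn3-c2ccc(F)cc2F)[C@H]1C` is reported only as a limit, > 500 ug/mL. For the measured compounds named here, compound 1 therefore stands well under the one other reading available.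

Compound 3 `CC(C)C[C@H](N)C(=O)N[C@@H]1CN(c2nc3c(cc2F)c(=O)c(C(=O)O)cn3C2CC2)[C@H]1C` keeps the core of compound 1 and differs from it in one place: (1-amino-3-methylbutyl)carbonyl in place of hydrogen on an amine nitrogen. The change puts (1-amino-3-methylbutyl)carbonyl in place of hydrogen on an amine nitrogen. Going by the values given here, no measured pair of compounds isolates a change of this kind, so its size in this assay remains uncertain. A rise beyond the usual scatter is nevertheless expected, an expectation that rests only on compound 2, whose reading is the limit > 500 ug/mL. The estimated change is a 9.1-fold higher number from compound 1 to compound 3 (0.96 log units; beyond the scatter). Compound 3 is estimated at 150 ug/mL, with an expected range of 40 ug/mL to 500 ug/mL.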

Compound 3, solubility: > 500 ug/mL
Compound 3: only a limit was reported; the forecaster's own chance of this, stated with the estimate: 15%; middle value at least 3.3-fold (0.52 log units) from the limit.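

Among the compounds shown here, on an amine nitrogen whose other neighbours are a saturated ring carbon, (1-amino-3-methylbutyl)carbonyl in place of hydrogen gives an at least 30-fold higher number from compound 1 to compound 3 (1.48 log units; beyond the scatter) in this assay, the first readable step at this position. This step is a floor and not a full size. Compound 3 is reported only as a limit, > 500 ug/mL, so the size of the change cannot be read beyond it, because the readings that count here stop at that limit: the limit of > 500 ug/mL in this assay, at which 2 of the 3 values shown sit.

From the compounds shown here alone, whether the amino group or the branched chain of the entering group carries the step stays open, since an acetyl or a plain 3-methylbutanoyl on the same nitrogen would be needed to separate them. Compound 2 differs from compound 1 in more than one place, so it cannot settle this.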